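Hydroxamate Arm Moved from Alkene onto a Benzene Ring

A few compounds are considered here, and "the series" means these few. Any claim that something is new, unique, unknown or untested is made for them only; others in the source may bear on it.

Compound 1 `O=C(/C=C/c1cn([C@@H]2C[C@H](CO)N(CCCc3ccccc3)C2)nn1)NO` in an assay on Sf9 cells for inhibition of histone deacetylase 11 (Homo sapiens), read by fluorescence, tested at 0.5 uM (on this read-out higher numbers stand for more inhibition at the one concentration tested (going by the name of the read-out) and lower numbers for less inhibition), gives 12%. Its stereoisomer compound 2 `O=C(/C=C/c1cn([C@H]2C[C@H](CO)N(CCCc3ccccc3)C2)nn1)NO` gives 16%, and compound 3 `O=C(/C=C/c1cn([C@@H]2C[C@H](C(=O)O)N(CCCc3ccccc3)C2)nn1)NO`, carrying carboxy in place of hydroxymethyl on a saturated ring carbon, gives 11%. All three sit in the same narrow band: a number 4 percentage points higher from compound 1 to compound 2 (within the scatter) and a number 1 percentage points lower from compound 1 to compound 3 (within the scatter). Given (the fact that compounds 1 and 2 differ only in the configuration as drawn), the first of these steps speaks only to configuration, and the second only to the group on the saturated ring carbon.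

Compound 4 `O=C(NO)c1ccc(-c2cn([C@@H]3C[C@H](CO)N(CCCc4ccccc4)C3)nn2)cc1` differs from compound 1 by 4-(hydroxycarbamoyl)phenyl in place of 2-(hydroxycarbamoyl)ethenyl on an aromatic carbon. Neither measured step touches the arm that bears the hydroxamic acid, so the numbers shown offer no direct guide to this change, and no shift beyond the scatter can be read from them. Compound 4 is therefore expected to give 12% in this assay, somewhere between -5% and 30%. The estimated step of no change at the digits printed from compound 1 to compound 4 (within the scatter) is expected to remain within the scatter.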

Compound 4, a percentage reported as inhibition, at one concentration (the size of the read-out at that concentration, not a potency): 15%
For compound 4 the middle estimate is 3 percentage points below the measured one; measured number inside the range.
By their numbers in this assay, from the lowest: compounds 3, 1, 4 and 2 (each within the scatter of the next).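

In this assay, the step at the aromatic carbon of the five-membered ring, with 4-(hydroxycarbamoyl)phenyl in place of 2-(hydroxycarbamoyl)ethenyl, gives a number 3 percentage points higher from compound 1 to compound 4 (within the scatter). Going by these compounds alone, this is the first change to the arm bearing the hydroxamic acid, and it shows that this position accepts the larger arm, with its six-membered aromatic ring of carbon only, while the read-out stays in the same narrow band as the earlier compounds. Nothing available for these compounds accounts for this result.

Still open, on these data alone, is what a carboxylic acid in place of the hydroxycarbamoyl group, a longer chain between the benzene ring and that group, or an amine on the benzene ring would give. Also open, as far as these compounds go, is whether the new arm would behave the same way with the configuration of compound 2 or the carboxy group of compound 3.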